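Aryl change from compound 2 to compound 3

The source may hold more compounds than are shown below. What is called first, only, known or untested is meant among the compounds shown, and "the series" means these compounds.

Among the measured compounds shown here, in a functional assay on A549 cells (Homo sapiens) for cytotoxicity (on this read-out lower numbers stand for stronger inhibition and higher numbers for weaker inhibition), compound 1 `C=C/C=C\[C@H](C)[C@H](OC(N)=O)[C@@H](C)[C@H](O)[C@@H](C)C/C(C)=C\[C@H](C)[C@@H](O)[C@@H](C)/C=C\CCc1ccc(C)c(F)c1` gives 4000 nM and compound 2 `C=C/C=C\[C@H](C)[C@H](OC(N)=O)[C@@H](C)[C@H](O)[C@@H](C)C/C(C)=C\[C@H](C)[C@@H](O)[C@@H](C)/C=C\CCc1cccc(O)c1C` gives 910 nM, the lower of the two numbers so far. For the measured compounds named here, the single measured step, a 4.4-fold lower number from compound 1 to compound 2 (0.64 log units; beyond the scatter), lies beyond the scatter.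

Going by the values given here, compound 3 `C=C/C=C\[C@H](C)[C@H](OC(N)=O)[C@@H](C)[C@H](O)[C@@H](C)C/C(C)=C\[C@H](C)[C@@H](O)[C@@H](C)/C=C\CCc1cccc(Cl)c1` has no measurement yet. Its structural difference from compound 2 is 3-chlorophenyl in place of 3-hydroxy-2-methylphenyl on a saturated chain carbon, two bonds along the chain from a double-bonded chain carbon. The change places 3-chlorophenyl in place of 3-hydroxy-2-methylphenyl, on a saturated chain carbon, two bonds along the chain from a double-bonded chain carbon.

Among the compounds with values here, only the one step bears on this change, and it is a different aryl exchange, so it gives a rough size rather than a rule. Compound 1 also has no hydroxy group on its phenyl and stands at 4000 nM, so a return towards that number is expected, though two compounds establish no trend. The expected change is a 2.7-fold higher number from compound 2 to compound 3 (0.44 log units; beyond the scatter), comparable to or smaller than the measured step. For compound 3 the estimated value is 2500 nM, with an expected range of 900 nM to 7000 nM.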

Compound 3, half-maximal inhibitory concentration: 580 nM
Compound 3: the middle estimate sits 4.3-fold (0.63 log units) above what was measured; measured number outside the range, below it.
By their numbers in this assay, from the lowest: compounds 3 and 2 (each within the scatter of the next); then compound 1.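

In this assay, the hydroxy group of 3-hydroxy-2-methylphenyl proves dispensable at this place on the saturated chain carbon: 3-chlorophenyl, with no hydrogen-bond donor or acceptor, gives a 1.6-fold lower number from compound 2 to compound 3 (0.20 log units; within the scatter), so the two aryl groups cannot be told apart on this read-out. Among the compounds shown here, the absence of a hydroxy group therefore does not by itself lead back to the number of compound 1, since compound 1 and compound 3 both lack one and yet the aryl exchange gives a 6.9-fold lower number from compound 1 to compound 3 (0.84 log units; beyond the scatter), leaving 3-fluoro-4-methylphenyl as the one aryl group of the three that separates from the others. Nothing measured here accounts for that separation.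

With only three aryl groups shown, it remains open whether plain phenyl, or a chlorine together with the methyl of compound 2, would stay level with compound 2 and compound 3. Also open, going by these compounds, is how this position responds to an amine or a carboxylic acid on the ring, or to a longer chain between the ring and the double-bonded chain carbon.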